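A few compounds are considered here, and "the series" means these few. Any claim that something is new, unique, unknown or untested is made for them only; others in the source may bear on it.

In a functional assay on MCF7 cells (Homo sapiens) for cytotoxicity, read by MTT assay, with a stated time of 72 h (a higher number here means a weaker inhibitor, a lower number a stronger inhibitor), three compounds have been measured. Compound 1 `CNC(=O)c1cc(Oc2ccc(NC(=O)c3nn(-c4ccccc4OC(F)(F)F)c(=O)cc3C)cc2F)ccn1` reaches only the limit > 40000 nM of this assay, and no number beyond that is reported for it. Compound 2 `Cc1cc(=O)n(-c2ccccc2C(F)(F)F)nc1C(=O)Nc1ccc(Oc2ncnc3ccsc23)cc1` gives 5550 nM. Compound 3 `Cc1cc(=O)n(-c2ccccc2C(F)(F)F)nc1C(=O)Nc1ccc(Oc2ncnc3ccsc23)c(F)c1` gives 6020 nM, the higher of the two actual numbers, but the step of a 1.1-fold higher number from compound 2 to compound 3 (0.04 log units; within the scatter) is within the scatter, so the two cannot be told apart. Going by the values given here, the only measured step therefore concerns a fluoro in place of hydrogen and changes nothing that can be trusted.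

Compound 4 `Cc1cc(=O)n(-c2ccccc2OC(F)(F)F)nc1C(=O)Nc1ccc(Oc2ncnc3ccsc23)c(F)c1` differs from compound 3 by trifluoromethoxy in place of trifluoromethyl on an aromatic carbon. Among the compounds with values here, no measured step covers this exchange, since compound 1 carries the trifluoromethoxy group on a different core and differs from compound 3 in more than one place, so its limit cannot be read as a step. Within the data shown here, the only bearing evidence is the limit of > 40000 nM in this assay, at which 1 of the 3 values shown sits, which shows that a compound with this group can sit beyond the range of this assay, without saying why.

The account therefore expects compound 4 to be estimated at 9000 nM, between 3000 nM and 30000 nM, in this assay, a step of a 1.5-fold higher number from compound 3 to compound 4 (0.17 log units; within the scatter) that is expected to be small and only weakly directed towards a higher number.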

Compound 4, half-maximal inhibitory concentration: 11500 nM
For compound 4 the middle estimate is 1.3-fold (0.11 log units) below the measured one, within the range that was stated.
By their numbers in this assay, from the lowest: compounds 2, 3 and 4 (each within the scatter of the next, the first and the last beyond it). At a limit, above all of these: compound 1.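

In this assay, trifluoromethoxy in place of trifluoromethyl, on an aromatic carbon ortho to a large group, gives a 1.9-fold higher number from compound 3 to compound 4 (0.28 log units; within the scatter), so on this shared core the two groups cannot be told apart at this position. Going by these compounds alone, compound 1 and compound 4 both carry trifluoromethoxy, so the group alone does not hold a compound at the limit; they differ in the group on the oxygen on an aromatic ring, and that exchange gives an at least 3.4-fold lower number from compound 1 to compound 4 (0.54 log units; beyond the scatter), the first step that lies beyond the scatter. Because compound 1 gives only a limit of the assay and not a number, this step has no fixed size, and its true extent stays unknown: the limit of > 40000 nM in this assay, at which 1 of the 4 values shown sits.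

The compounds shown hold no methoxy group, chlorine atom or plain hydrogen at this position, so it remains open whether anything placed there would move the number beyond the scatter. Going by these compounds, it is also open which part of the group on the oxygen carries the step, and how an amine or a carboxylic acid on that group would read in this assay.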